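The source may report more compounds than this note shows. Statements on the series, on what has been measured and on what is new or still open speak of the compounds shown alone.

Measured so far:
Compound 1 `COc1ccc(C(=O)/C=C/c2ccc(F)cc2)c(O)c1` gives 81.2% in an assay on isolated protein for inhibition of DNA topoisomerase 1 (Homo sapiens), tested at 100 uM; on this read-out lower numbers stand for a weaker effect and higher numbers for a stronger effect at the one concentration tested.
Compound 2 `COc1cc(O)ccc1/C=C/C(=O)c1ccc(NC(C)=O)cc1` gives 100% in this assay.

Of these two numbers, compound 1 stands lowest; compound 2 lies higher by a margin beyond the usual scatter of repeated measurements, so the two compounds are genuinely told apart here. Compound 3 `O=C(/C=C/c1ccc(F)cc1)c1ccc(O)cc1O` is the one not yet measured. It differs from compound 1 in a single place: hydrogen in place of methyl on an oxygen on an aromatic ring. Within the data shown here, no measured pair shows this change on its own, so nothing in the numbers at hand says how large its effect is. The expectation is therefore a cautious one: a step of about a number 0.8 percentage points higher from compound 1 to compound 3 (within the scatter) is expected, which means no change beyond the scatter in either direction. On that basis compound 3 is expected to reach 82% in this assay, with a range from 60% to 100%.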

Compound 3, a percentage reported as inhibition, at one concentration (the size of the read-out at that concentration, not a potency): 80.2%
Estimate against measurement, compound 3: 1.8 percentage points above; the measured number falls inside the stated range.
By their numbers in this assay, from the lowest: compounds 3 and 1 (each within the scatter of the next); then compound 2.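

In this assay, among these compounds, replacing methoxy with hydroxy on this aromatic ring gives a number 1 percentage points lower from compound 1 to compound 3 (within the scatter) and so provides the first direct reading of this change. In this setting, the methyl on this oxygen can therefore be replaced by hydrogen without a difference that this read-out can tell apart at the one concentration tested. Nothing measured here gives a reason for this result.

On these data alone, it remains open whether an ethyl group or a longer chain on this oxygen, or an amine in place of the methoxy, would shift the number beyond the scatter. Compound 2 also carries a methoxy group, but in a different setting, so whether the same change would behave alike there is also unresolved.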